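Acetyl for nitro: working notes on the series

The source may report more compounds than this note shows. Statements on the series, on what has been measured and on what is new or still open speak of the compounds shown alone.

compound 1 `O=[N+]([O-])c1ccc(-c2nc3cc(C(F)(F)F)ccc3[nH]2)cc1`: 45000 nM
compound 2 `COc1ccc(-c2nc3cc([N+](=O)[O-])ccc3[nH]2)c(OC)c1`: > 100000 nM (a limit)
compound 3 `COc1ccc(-c2nc3cc([N+](=O)[O-])ccc3[nH]2)c(OC)c1OC`: > 100000 nM (a limit)

In an ADME assay on Vero cells (Chlorocebus sabaeus) for cytotoxicity (on this read-out lower numbers stand for higher toxicity in this test and higher numbers for lower toxicity in this test), compound 3 gives > 100000 nM, which is a limit and not a number. Compound 2 gives > 100000 nM, also a limit. The series therefore shows (the limit of > 100000 nM in this assay, at which 2 of the 3 values shown sit). Only compound 1 gives a number in this assay, at 45000 nM.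

The next structure is compound 4 `COc1ccc(-c2nc3cc(C(C)=O)ccc3[nH]2)c(OC)c1OC`. The change is acetyl in place of nitro on an aromatic carbon, in words acetyl in place of nitro on an aromatic carbon.

Going by the values given here, the one measured step between close neighbours is a step that the two limits leave unreadable from compound 2 to compound 3. That step is methoxy in place of hydrogen on an aromatic carbon, so it is a different change, and it gives no size to carry over. Among the compounds with values here, no measured step replaces nitro on the shared core. The expectation for this assay therefore starts from the limit of compound 3, with no firm direction and no shift expected beyond the scatter. The expected step is an at least 1.1-fold lower number from compound 3 to compound 4 (0.04 log units; that floor lies within the scatter). For compound 4 the estimated value is 90000 nM, with an expected range of 35000 nM to 250000 nM.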

Compound 4, half-maximal cytotoxic concentration: > 100000 nM
Compound 4: only a limit was reported (the forecaster's own chance of this, stated with the estimate: 60%); at least 1.1-fold (0.04 log units) between middle value and limit.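

In this assay compound 4 gives > 100000 nM, which is a limit and not a number. Compound 3 also stands at a limit, so no step can be read between compound 3 and compound 4: the limit of > 100000 nM in this assay, at which 3 of the 4 values shown sit.

The compounds shown leave open whether acetyl in place of nitro shifts the half-maximal cytotoxic concentration at all, and in which direction.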